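An Amine for a Nitro on an Aryl Amide

The source may report more compounds than this note shows. Statements on the series, on what has been measured and on what is new or still open speak of the compounds shown alone.

Compound 1 `COc1ccc(OC(=O)c2cc(OC)c(OC)c(OC)c2)cc1[N+](=O)[O-]`: > 100000 nM
Compound 2 `COc1ccc(OC(=O)c2cc(OC)c(OC)c(OC)c2)cc1N`: > 100000 nM
Compound 3 `COc1ccc(C(=O)Nc2cc(OC)c(OC)c(OC)c2)cc1[N+](=O)[O-]`: 2000 nM

Of the compounds shown here, three have been measured in a functional assay on HCT-15 cells (Homo sapiens) for antiproliferative activity, read by MTT assay, with a stated time of 72 h; on this read-out higher numbers stand for weaker inhibition and lower numbers for stronger inhibition. For compound 1 the value > 100000 nM is a limit of the assay, not a number. For compound 2 the value > 100000 nM is likewise a limit. For the measured compounds named here, compound 3 gives 2000 nM in this assay, the only number among the three. The change from compound 1 to compound 2 is amino in place of nitro on an aromatic carbon; its step that the two limits leave unreadable from compound 1 to compound 2 cannot be read because both values sit at the limit of > 100000 nM in this assay, at which 2 of the 3 values shown sit. The difference between the cores of compound 1 and compound 3 is not broken down here. Compound 4 `COc1ccc(C(=O)Nc2cc(OC)c(OC)c(OC)c2)cc1N` is not yet measured; it differs from compound 3 by amino in place of nitro on an aromatic carbon, the same change in the same place. Because the step that the two limits leave unreadable from compound 1 to compound 2 gives no size, the expectation leans on compound 3 and its value 2000 nM. Compound 4 is expected to give 3000 nM, between 500 nM and 20000 nM, an expected step of a 1.5-fold higher number from compound 3 to compound 4 (0.18 log units; within the scatter).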

Compound 4, half-maximal inhibitory concentration: > 100000 nM
Compound 4: a limit, no number; the forecaster's own chance of this, stated with the estimate: 15%; middle value at least 33-fold (1.52 log units) from the limit.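

In this assay, amino in place of nitro on an aromatic carbon brings an at least 50-fold higher number from compound 3 to compound 4 (1.69 log units; beyond the scatter). Compound 4 gives > 100000 nM, which is a limit of the assay and not a number, so the step has no upper size. The same change on the core of compound 1 cannot be read, so no size can be carried from one core to the other, and the two cores agree only in that both amino compounds end at the same limit: the limit of > 100000 nM in this assay, at which 3 of the 4 values shown sit.

The compounds shown leave open whether this loss belongs to amino itself or would follow any group that replaces nitro on the core of compound 3. A nitrile, an acetamide or plain hydrogen in that place would separate these readings.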